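The source may hold more compounds than are shown below. What is called first, only, known or untested is meant among the compounds shown, and "the series" means these compounds.

Measured compounds in a functional assay on SK-MEL-28 cells (Homo sapiens) for cytotoxicity, read by MTT assay; a higher number here means a weaker inhibitor, a lower number a stronger inhibitor:

Compound 1 `O=S(=O)(NCCCNc1nccc(-c2c(-c3cccc(F)c3)nc3sccn23)n1)c1cccc(F)c1` gives 8550 nM.
Compound 2 `O=S(=O)(NCCCNc1nccc(-c2c(-c3cccc(F)c3)nc3sccn23)n1)c1ccc(Br)cc1` gives 9400 nM.
Compound 3 `Cc1ccc(S(=O)(=O)NCCNc2nccc(-c3c(-c4cccc(F)c4)nc4sccn34)n2)cc1` reaches only the limit of > 20000 nM, so no number is available for it.

Compound 2 stands at the higher of the two numbers, with compound 1 nearest, and the step of a 1.1-fold higher number from compound 1 to compound 2 (0.04 log units; within the scatter) sits within the scatter. Compound 3 sits at the limit, described by the limit of > 20000 nM in this assay, at which 1 of the 3 values shown sits; the steps of an at least 2.3-fold higher number from compound 1 to compound 3 (0.36 log units; beyond the scatter) and an at least 2.1-fold higher number from compound 2 to compound 3 (0.32 log units; beyond the scatter) are at least modest and run toward weaker inhibition.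

Compound 4 `O=C(NCCCNc1nccc(-c2c(-c3cccc(F)c3)nc3sccn23)n1)c1ccc(Cl)cc1` is not yet measured. It differs from compound 2 as (4-chlorophenyl)carbonyl in place of (4-bromophenyl)sulfonyl on an amine nitrogen. Going by the values given here, of the measured steps, only the one from compound 1 to compound 2 concerns the aryl group on the sulfonyl sulfur, and that swap of 4-bromophenyl for 3-fluorophenyl stayed within the scatter. The steps to compound 3 alter the chain as well as the aryl group and do not isolate the change at hand. Among the compounds with values here, no measured step covers the exchange of a sulfonyl for a carbonyl on the amine nitrogen, so no direction beyond the scatter can be argued from the data; the range must stay wide.

Compound 4 is therefore estimated at 9400 nM, between 3500 nM and 25000 nM. The expected step is no change at the digits printed from compound 2 to compound 4 (within the scatter).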

Compound 4, half-maximal inhibitory concentration: > 20000 nM
Compound 4: a limit, no number; the forecaster's own chance of this, stated with the estimate: 30%; middle value at least 2.1-fold (0.32 log units) from the limit.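

In this assay the change now reaches the sulfonyl on the amine nitrogen itself, not only the aryl group it carries: compound 4, with (4-chlorophenyl)carbonyl in place of (4-bromophenyl)sulfonyl, sits at > 20000 nM, which is a limit of the assay and not a number. This exchange gives an at least 2.1-fold higher number from compound 2 to compound 4 (0.32 log units; beyond the scatter) and an at least 2.3-fold higher number from compound 1 to compound 4 (0.36 log units; beyond the scatter), both toward weaker inhibition, whereas the aryl swap on the sulfonyl sulfur alone gave a 1.1-fold higher number from compound 1 to compound 2 (0.04 log units; within the scatter), so among these compounds this position tolerates the aryl exchange but not this replacement of the whole sulfonyl group. Compound 3 and compound 4 both end at the limit, so the step between them cannot be read: the limit of > 20000 nM in this assay, at which 2 of the 4 values shown sit.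

The carbonyl and the 4-chlorophenyl enter together, so the compounds shown do not separate the part played by each, and the distance of compound 4 beyond the limit remains unknown. Also open, as far as these compounds go, is how a urea on the same amine nitrogen, or a longer chain carrying the sulfonyl group, would read in this assay.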